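The compounds below may be only part of what the source reports. "The series", "measured", "known", "first", "only" and "open" are said of these compounds alone.

Compound 2 `CSCC[C@@H](NC(=O)c1cccc(C(=N)N)c1)C(=O)NCC1CCC(CN)CC1` carries a sulfur-bearing side chain on the carbon that sits between the amide of the amidine-substituted benzamide and the carbonyl that links to the aminomethyl-cyclohexyl tail. In an assay on isolated protein for binding affinity to serine protease 1 (Homo sapiens) (a higher number here means a weaker inhibitor, a lower number a stronger inhibitor), compound 2 gives 10000 nM, the higher of the two numbers recorded, and therefore the weaker of the two measured inhibitors. Going by the values given here, the only other measured compound, compound 1 `N=C(N)c1cccc(C(=O)N[C@@H](C(=O)N2CCC(Cc3ccccc3)CC2)c2ccccc2)c1`, with a phenyl group in place of that side chain and a different tail, gives 650 nM in this assay, a gap that lies well beyond the usual scatter.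

Compound 3 `CSCC[C@H](NC(=O)c1cccc(C(=N)N)c1)C(=O)NCC1CCC(CN)CC1` is built from exactly the same atoms and bonds as compound 2; the change is the two compounds have the same atoms and bonds; at least one stereo element is drawn with a configuration in one of them and without one in the other: 1 of 4 stereo elements differ; a stereocentre at a saturated chain carbon is drawn R in compound 2 and S in compound 3, so the two are mirror images at that single centre. Among the compounds with values here, no measured pair in this set shows what such an inversion does. Compound 3 is expected to be a weak inhibitor as well, with a step from compound 2 of about a 1.5-fold higher number from compound 2 to compound 3 (0.18 log units; within the scatter), toward a higher number or no change beyond the scatter. In this assay compound 3 is estimated at 15000 nM, within a range of 4000 nM to 60000 nM.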

Compound 3, inhibition constant: 7900 nM
Estimate against measurement, compound 3: 1.9-fold (0.28 log units) above; the measured number falls inside the stated range.
By their numbers in this assay, from the lowest: compound 1; then compounds 3 and 2 (each within the scatter of the next).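

Inverting the one stereocentre at the saturated chain carbon gives a 1.3-fold lower number from compound 2 to compound 3 (0.10 log units; within the scatter), the first measured step in this set and the first direct look at what the drawn configuration at this carbon does. In this assay, with the sulfur-bearing side chain and the aminomethyl-cyclohexyl tail held fixed, the R and S drawings cannot be told apart, so this series offers no evidence that the drawn configuration at this carbon matters for the read-out. One caution applies to that reading, and it sets a limit on how firmly the two drawings can be treated as distinct forms: the fact that one of compounds 2 and 3 is drawn with a defined configuration and the other without, at the place where they differ

The compounds shown leave open whether the same indifference to configuration would hold with a different group at this carbon, such as a carboxylic acid, an amine or a longer chain in place of the sulfur-bearing side chain. They also leave open whether inverting the matching carbon in compound 1, which carries a phenyl group there and a different tail, would give a step beyond the scatter.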